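This account rests on a few compounds, and the source may have more. Where it says the series, first, only, none or still open, it means among the compounds named here.

Compound 2 `O=C(NNC(=O)c1ccc2[nH]c(-c3ccc([N+](=O)[O-])o3)nc2c1)c1cccc(Oc2ccccc2)c1` gives in an ADME assay on NIH3T3 cells (Mus musculus) for inhibition, read by sulforhodamine B assay, with a stated time of 48 h (a lower number here means a stronger inhibitor of growth, a higher number a weaker inhibitor of growth), only a limit, > 7.8 ug/mL. Compound 1 `COc1cccc(C(=O)NNC(=O)c2ccc3[nH]c(-c4ccc([N+](=O)[O-])o4)nc3c2)c1` gives 15.6 ug/mL in this assay. Among the measured compounds shown here, the single measured step, a step that the limit leaves unreadable from compound 1 to compound 2, has no readable size because of the limit of > 7.8 ug/mL in this assay, at which 1 of the 2 values shown sits. Compound 3 `O=C(NNC(=O)c1ccc2[nH]c(-c3ccc([N+](=O)[O-])o3)nc2c1)c1ccccc1` differs from compound 2 by hydrogen in place of phenoxy on an aromatic carbon. For the measured compounds named here, no measured step covers this change, so no direction beyond the scatter is supported, and the only number that is not a limit belongs to compound 1. Compound 3 is expected to fall near 18 ug/mL in this assay, within 6 ug/mL to 55 ug/mL. The step this implies, a step that the limit leaves unreadable from compound 2 to compound 3, is an estimate that a limit cannot check.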

Compound 3, concentration for 50% growth inhibition: 31.3 ug/mL
Estimate against measurement, compound 3: 1.7-fold (0.24 log units) below; low and high end bracket the measured number.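

In this assay, among the compounds shown here, exchanging methoxy for hydrogen gives a 2.0-fold higher number from compound 1 to compound 3 (0.30 log units; within the scatter), the first readable step at this position. Methoxy can therefore be removed here without a change beyond the scatter. The steps involving compound 2 cannot be read, as its value is only a limit: the limit of > 7.8 ug/mL in this assay, at which 1 of the 3 values shown sits.

On these data alone, whether phenoxy shifts the number in either direction remains open. Also open, as far as these compounds go, is how an amine or a carboxylic acid on this aromatic carbon would read in this assay.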